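The source may report more compounds than this note shows. Statements on the series, on what has been measured and on what is new or still open speak of the compounds shown alone.

Measured values in an ADME assay on microsomes from liver (Rattus norvegicus) for metabolic stability; a lower number here means that the compound disappears faster, a higher number that the compound lasts longer:

compound 1 `CC(C)C(c1ccc(-c2ccc3cccc(F)c3c2)[nH]c1=O)C1C(=O)NC(=O)N1C` gives 0.263 h
compound 2 `CC(C)C(/C=C1\NC(=O)NC1=O)c1ccc(-c2ccc3cccc(F)c3c2)[nH]c1=O` gives 1.46 h
compound 3 `CC(C)/C(=C1\NC(=O)OC1=O)c1ccc(-c2ccc3cccc(F)c3c2)[nH]c1=O` gives > 3 h, which is a limit of this assay and not a number

Compound 2 holds the highest of the two numbers shown in this assay; its nearest neighbour is compound 1, with a 5.6-fold higher number from compound 1 to compound 2 (0.74 log units; beyond the scatter). The remaining value, that of compound 3, sits at the limit of > 3 h in this assay, at which 1 of the 3 values shown sits.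

Compound 4 `CC(C)C(/C=C1\SC(=O)NC1=O)c1ccc(-c2ccc3cccc(F)c3c2)[nH]c1=O` is the next member. Relative to compound 2 the change is a group of 8 heavy atoms (4 carbon, 1 nitrogen, 2 oxygen, 1 sulfur; one five-membered non-aromatic ring with 2 hetero atoms) in place of a group of 8 heavy atoms (4 carbon, 2 nitrogen, 2 oxygen; one five-membered non-aromatic ring with 2 hetero atoms), on a saturated chain carbon bound to an aromatic carbon and a saturated chain carbon. Within the data shown here, only one measured step touches the same saturated chain carbon, the exchange of one five-membered ring for another from compound 1 to compound 2, and it was modest in size. Among the measured compounds shown here, no measured step exchanges a ring nitrogen for a ring sulfur, so the present change has no direct precedent; compound 3, which carries oxygen in that ring, shows only a limit, which neither fixes a size nor rules one out. The step expected in this assay is therefore small, likely within the scatter, with a slight lean upward: a 1.4-fold higher number from compound 2 to compound 4 (0.14 log units; within the scatter). Compound 4 is estimated at 2 h, with a range from 0.9 h to 4.5 h.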

Compound 4, half-life: 2.62 h
For compound 4 the middle estimate is 1.3-fold (0.12 log units) below the measured one; measured number inside the range.
By their numbers in this assay, from the lowest: compound 1; then compounds 2 and 4 (each within the scatter of the next). At a limit, above all of these: compound 3.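

In this assay, among these compounds, exchanging a ring nitrogen for a ring sulfur on this saturated chain carbon gives a 1.8-fold higher number from compound 2 to compound 4 (0.25 log units; within the scatter), so this exchange yields no step that can be told from the scatter. The wider exchange of five-membered rings on the same carbon gives a 10-fold higher number from compound 1 to compound 4 (1.00 log units; beyond the scatter), which joins a 5.6-fold higher number from compound 1 to compound 2 (0.74 log units; beyond the scatter) as a second step beyond the scatter, with the number higher both times. Compound 3 remains a limit of this assay and not a number: the limit of > 3 h in this assay, at which 1 of the 4 values shown sits.

Any step involving compound 3 cannot be read, so the oxygen-bearing ring cannot be placed against the ring holding nitrogen or the ring holding sulfur. Also open, going by these compounds, is how a carboxylic acid or a primary amine in place of the five-membered ring, on this same saturated chain carbon, would read in this assay, and whether the higher numbers seen with these two ring exchanges would carry over to any group outside this small set of rings.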